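One ring swapped on a carbonyl carbon

The compounds below may be only part of what the source reports. "The series", "measured", "known", "first", "only" and "open" are said of these compounds alone.

- Compound 1 `O=C(Nc1c(O)cccc1-c1nc2c(C(=O)O)cccc2o1)c1ncccc1F`: 204000 nM
- Compound 2 `O=C(Nc1c(O)cccc1-c1nc2c(C(=O)O)cccc2o1)c1ccccc1O`: 85100 nM

For the measured compounds named here, in an ADME assay on L6 cells (Rattus norvegicus) for cytotoxicity (a higher number here means a weaker inhibitor, a lower number a stronger inhibitor), compound 2 has the lower of the two numbers so far, 85100 nM. Compound 3 `O=C(Nc1c(O)cccc1-c1nc2c(C(=O)O)cccc2o1)c1cccc(Cl)c1` has 3-chlorophenyl in place of 2-hydroxyphenyl on a carbonyl carbon. Going by the values given here, only one measured step changes this same place, and it is modest: a 2.4-fold lower number from compound 1 to compound 2 (0.38 log units; beyond the scatter). That step does not involve 3-chlorophenyl, so it points in no clear direction, and no change beyond the scatter is expected in this assay. The expected result is a 1.1-fold higher number from compound 2 to compound 3 (0.02 log units; within the scatter). The estimate for compound 3 is 90000 nM, with an expected range from 35000 nM to 220000 nM.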

Compound 3, half-maximal inhibitory concentration: 143000 nM
Compound 3: middle estimate off by 1.6-fold (0.20 log units), on the low side; low and high end bracket the measured number.
By their numbers in this assay, from the lowest: compounds 2, 3 and 1 (each within the scatter of the next, the first and the last beyond it).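

In this assay, putting 3-chlorophenyl, with no hydrogen-bond donor or acceptor, in place of 2-hydroxyphenyl gives a 1.7-fold higher number from compound 2 to compound 3 (0.23 log units; within the scatter) and so does not separate the two compounds. Putting it in place of 3-fluoropyridin-2-yl gives a 1.4-fold lower number from compound 1 to compound 3 (0.15 log units; within the scatter) and does not separate those two either, so compound 3 cannot be told apart from compound 1 or compound 2, though those two differ beyond the scatter. No measured evidence accounts for these numbers.

Still open, going by these compounds, is whether an amine or a longer alkyl chain on this carbonyl carbon would produce a step beyond the scatter from compound 3.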